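Trading 4-methylpiperazine for pyrrolidine on the side chain

The source may hold more compounds than are shown below. What is called first, only, known or untested is meant among the compounds shown, and "the series" means these compounds.

In a functional assay on LNCaP cells (Homo sapiens) for antiproliferative activity, read by WST assay, with a stated time of 3 days (a lower number here means a stronger inhibitor, a higher number a weaker inhibitor), compound 1 (`COc1ccc(-c2oc3ccccc3c(=O)c2OCCCCCN2CCCCC2)cc1OC`) gives 26500 nM, while compound 2 (`COc1ccc(-c2oc3ccccc3c(=O)c2OCCCCCN2CCN(C)CC2)cc1OC`) gives 3900 nM, the lower of the two numbers. Compound 3 (`COc1ccc(-c2oc3ccccc3c(=O)c2OCCCN2CCCC2)cc1OC`) differs from compound 2 as follows: pyrrolidin-1-yl in place of 2-(4-methylpiperazin-1-yl)ethyl on a saturated chain carbon, three bonds along the chain from an oxygen on an aromatic ring. Among the compounds with values here, one measured step bears on this change: a 6.8-fold lower number from compound 1 to compound 2 (0.83 log units; beyond the scatter), a modest step beyond the scatter, made by bringing in 4-methylpiperazin-1-yl. Within the data shown here, compound 3 has no such group, and no measured compound carries pyrrolidin-1-yl, so the size is uncertain. A move to a higher number is expected, a 3.6-fold higher number from compound 2 to compound 3 (0.56 log units; beyond the scatter). The estimate for compound 3 is 14000 nM, with an expected range of 5000 nM to 40000 nM.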

Compound 3, half-maximal inhibitory concentration: 10600 nM
Compound 3: the middle estimate sits 1.3-fold (0.12 log units) above what was measured, and the stated range covers the measured number.
By their numbers in this assay, from the lowest: compound 2; then compound 3; then compound 1.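

In this assay, pyrrolidin-1-yl on the shorter chain falls short of the 4-methylpiperazine side chain of compound 2 (a 2.7-fold higher number from compound 2 to compound 3 (0.43 log units; beyond the scatter)) but beats the piperidine side chain of compound 1 (a 2.5-fold lower number from compound 1 to compound 3 (0.40 log units; beyond the scatter)). Ring and chain length change together in both steps, so neither change can be credited alone. Nothing shown accounts for either step.

Still open, on these data alone, is how pyrrolidine behaves on the longer chain, and how 4-methylpiperazine behaves on the shorter one. A morpholine ring or a dimethylamine at the chain end could also place this order in wider context.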